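Swapping Methyl for Propyl on a Dihydropyrimidinone Ester

The compounds below may be only part of what the source reports. "The series", "measured", "known", "first", "only" and "open" are said of these compounds alone.

Three related compounds have been tested in an assay on membranes from HeLa cells for displacement of a labelled ligand from adenosine receptor A3 (Homo sapiens), read by scintillation counting, with a stated time of 180 min, tested at 1 uM; on this read-out higher numbers stand for more inhibition at the one concentration tested (going by the name of the read-out) and lower numbers for less inhibition. Compound 1 `CCCOC(=O)C1=C(C)NC(=O)NC1c1ccsc1` gives 6%. Compound 2 `CCCOC(=O)C1=C(C)N(C)C(=O)NC1c1ccoc1` gives 16%. Compound 3 `COC(=O)C1=C(C)N(C)C(=O)NC1c1ccsc1` gives 22%, the highest of the three numbers, although compound 2 sits within the usual scatter of it and only the gap to compound 1 is beyond the scatter. Compound 4 `CCCOC(=O)C1=C(C)N(C)C(=O)NC1c1ccsc1` has not yet been measured. It differs from compound 3 in one place: ethyl in place of hydrogen on a saturated chain carbon bound to an oxygen next to a carbonyl group. Among the compounds with values here, no measured pair shows this change alone, so its effect here is open. Compound 2 already carries a propoxycarbonyl group and gives 16%. A small step of a number 5 percentage points lower from compound 3 to compound 4 (within the scatter) is therefore expected, not beyond the scatter. Compound 4 is estimated at 17%, ranging from 5% to 30%.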

Compound 4, a percentage reported as inhibition, at one concentration (the size of the read-out at that concentration, not a potency): 11%
Compound 4: middle estimate off by 6 percentage points, on the high side; measured number inside the range.
By their numbers in this assay, from the lowest: compounds 1, 4, 2 and 3 (each within the scatter of the next, the first and the last beyond it).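

In this assay the change from methoxycarbonyl to propoxycarbonyl can now be read alone, and a number 11 percentage points lower from compound 3 to compound 4 (beyond the scatter) shows that the longer ester chain goes with less inhibition at this position. The other two single changes are smaller: thiophen-3-yl in place of furan-3-yl gives a number 5 percentage points lower from compound 2 to compound 4 (within the scatter) and methyl in place of hydrogen on the amide-type nitrogen in the ring gives a number 5 percentage points higher from compound 1 to compound 4 (within the scatter) and neither is a clear shift. Nothing measured here accounts for the drop with the longer chain. Going by these compounds, one step sets no trend, so ethoxycarbonyl, butoxycarbonyl and a carboxylic acid at this place remain open.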